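The compounds below may be only part of what the source reports. "The series", "measured", "known", "first", "only" and "open" are said of these compounds alone.

Among the compounds with values here, compound 1 `COc1cc(OCc2cccc(COc3ccccc3)c2)c2cc(-c3cn4nc(OC)sc4n3)oc2c1` is one of three compounds measured in a functional assay on HEK293 cells for antagonist activity at proteinase-activated receptor 4 (Homo sapiens), read by FLIPR and calcium flux, with a stated time of 30 min; on this read-out lower numbers stand for stronger inhibition and higher numbers for weaker inhibition. In this assay compound 1 gives 3.2 nM. Compound 3 `COc1cc(OCc2ccccc2OCc2ccccc2)c2cc(-c3cn4nc(OC)sc4n3)oc2c1` gives 3.2 nM in this assay, the same number at the digits printed, so the two sit together at the low end of the set, and nothing separates them within the usual scatter. Compound 2 `CS(=O)(=O)c1nn2cc(-c3cc4ccccc4o3)nc2s1`, a far smaller molecule that carries a methylsulfonyl group instead of a methoxy group on the core and has no side chain on the benzofuran, gives 820 nM in this assay, a much higher number, well beyond the scatter.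

Compound 4 `COc1cc(OCc2cccc(Sc3ccccc3)c2)c2cc(-c3cn4nc(OC)sc4n3)oc2c1` has not yet been measured. It differs from compound 1 in one place: phenylsulfanyl in place of phenoxymethyl on an aromatic carbon. Within the data shown here, no measured pair in this set shows this kind of exchange, so there is no direct guide for its size. Because compound 1 gives 3.2 nM and compound 3, with a differently placed side chain, gives 3.2 nM, the side chain seems to tolerate variation. The expected step of a 1.9-fold higher number from compound 1 to compound 4 (0.27 log units; within the scatter) is small, in the direction of a slightly higher number, and may well fall within the scatter. Compound 4 is therefore estimated at 6 nM, with a range from 1.5 nM to 30 nM.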

Compound 4, half-maximal inhibitory concentration: 0.89 nM
Compound 4: middle estimate off by 6.7-fold (0.83 log units), on the high side; measured number outside the range, below it.
By their numbers in this assay, from the lowest: compound 4; then compounds 1 and 3 (each within the scatter of the next); then compound 2.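

In this assay, phenylsulfanyl in place of phenoxymethyl on this aromatic carbon gives a 3.6-fold lower number from compound 1 to compound 4 (0.56 log units; beyond the scatter), showing that the number at this position responds to the choice of group, and that the response here runs toward stronger inhibition. The exchange is small on paper: the entering group has 7 heavy atoms and the leaving group 8, both keep one six-membered aromatic ring of carbon only, and each has 1 hydrogen-bond acceptor, with sulfur standing in for oxygen and one carbon gone. Nothing measured here explains the gain, and this single exchange cannot separate the effect of the sulfur from that of the lost carbon.

The compounds shown leave open whether the same change would have a similar effect with the side chain placed as in compound 3, since no such pair is available. They also leave open how the number would respond to other groups at this position, such as phenylsulfonyl, an anilino group with nitrogen as the link, or a longer chain such as 2-phenylethyl.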